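Changing the double-bond geometry of an aminostilbene retinoid

The compounds below may be only part of what the source reports. "The series", "measured", "known", "first", "only" and "open" are said of these compounds alone.

Measured compounds in a functional assay on HL-60 cells (Homo sapiens), with a stated time of 48 h; a higher number here means that more compound is needed for the effect, a lower number that less compound is needed:
compound 1, `CC1(C)CCC(C)(C)c2cc(/C=C/c3ccc(N)cc3)ccc21`, 38000 nM
compound 2, `CC1(C)CCC(C)(C)c2cc(/C=C/c3cccc(N)c3)ccc21`, 40000 nM
compound 3, `COc1ccc(/C=C(\C)c2ccc3c(c2)C(C)(C)CCC3(C)C)cc1N`, 40000 nM

Compound 1 stands alongside the other two rather than apart from them. The step of a 1.1-fold higher number from compound 1 to compound 2 (0.02 log units; within the scatter) is within the scatter, and compound 3, with a methyl on the chain and a methoxy beside the amine, gives a number for which the distance from compound 1 is likewise within the scatter. The three numbers therefore form a single cluster in this assay.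

Compound 4, `CC1(C)CCC(C)(C)c2cc(/C=C\c3ccc(N)cc3)ccc21`, is built from compound 1 by a change that touches no atom and no bond: the two compounds have the same atoms and bonds and differ only in configuration as drawn: 1 of 1 stereo elements differ; a double bond is drawn E in compound 1 and Z in compound 4. Among the compounds with values here, none of the measured steps concerns this kind of change; the single step available, from compound 1 to compound 2, moves the amine around the ring and leaves the double bond untouched, and the cluster of values gives no hint of how geometry matters here. The expectation for this assay is accordingly a step of no clear direction, with a wide range to cover the lack of any guiding step, estimated as a 1.1-fold higher number from compound 1 to compound 4 (0.02 log units; within the scatter).

Compound 4 is expected to give about 40000 nM, between 10000 nM and 150000 nM.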

Compound 4, concentration for half-maximal activity: 38000 nM
Compound 4: the middle estimate sits 1.1-fold (0.02 log units) above what was measured; the measured number falls inside the stated range.
By their numbers in this assay, from the lowest: compounds 1, 4, 2 and 3 (each within the scatter of the next).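

In this assay, within the data shown here, the pair gives the first direct reading on the double-bond geometry itself: no change at the digits printed from compound 1 to compound 4 (within the scatter). With the 4-aminophenyl group in place, drawing the double bond Z rather than E therefore leaves compound 4 in the same single cluster as the other three compounds, something the earlier step could not show, since it moved the amine and left the double bond untouched. The reading concerns this one change alone, with no other difference in the pair to account for it: the fact that compounds 1 and 4 differ only in the configuration as drawn

On these data alone, whether the same holds with a different group in place of the amine, such as a carboxylic acid, stays open, as does whether a number outside this cluster would then make the geometry count. Also open, as far as these compounds go, is whether the Z form would stay in the cluster with the 3-aminophenyl group of compound 2, or with the chain methyl and the methoxy group of compound 3.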